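The source may hold more compounds than are shown below. What is called first, only, known or untested is meant among the compounds shown, and "the series" means these compounds.

Three compounds have so far been measured in an assay on isolated protein for displacement of a labelled ligand from metabotropic glutamate receptor 5 (Homo sapiens), with a stated time of 60 min, tested at 1 uM; on this read-out higher numbers stand for more inhibition at the one concentration tested (going by the name of the read-out) and lower numbers for less inhibition:

Compound 1 `COc1ccc(S(=O)(=O)c2cnc3ccc(C)cc3c2N2CCC(C)CC2)cc1` gives 62% in this assay.
Compound 2 `COc1ccc2ncc(S(=O)(=O)c3ccc(Cl)cc3)c(N3CCC(C)CC3)c2c1` gives 91% in this assay.
Compound 3 `COCC1CCN(c2c(S(=O)(=O)c3ccc(F)cc3)cnc3cc(F)ccc23)CC1` gives 76.1% in this assay.

On these numbers compound 2 stands highest in this assay. The nearest number is that of compound 3, which lies lower by a margin beyond the usual scatter, and the number of compound 1 lies further below, again beyond the scatter. No two of the three measured compounds differ in only one place, so nothing can yet be said about what a single change does to the read-out; the three numbers stand on their own.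

Compound 4 `COc1ccc2ncc(S(=O)(=O)c3ccc(C)cc3)c(N3CCC(C)CC3)c2c1` has not yet been measured in this assay. It differs from compound 2 in one place: methyl in place of chloro on an aromatic carbon. The group that leaves and the group that enters are each a single heavy atom, carry no ring, and change neither the count of hydrogen-bond donors nor that of acceptors, nor the net charge.

Going by the values given here, with no measured pair of this kind to lean on, the step expected in this assay is a small one, pointing downward, and possibly not beyond the scatter. The step from the measured number to the estimate, a number 9 percentage points lower from compound 2 to compound 4 (within the scatter), is expected to be modest. Compound 4 is therefore estimated to give 82% in this assay, with a likely range from 65% to 95%.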

Compound 4, a percentage reported as inhibition, at one concentration (the size of the read-out at that concentration, not a potency): 90%
Estimate against measurement, compound 4: 8 percentage points below; the range from low to high includes it.
By their numbers in this assay, from the lowest: compound 1; then compound 3; then compounds 4 and 2 (each within the scatter of the next).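

Going by these compounds alone, compound 2 and compound 4 form the first pair in this account that differs in one place, and so give the first direct reading of a single change. In this assay, putting methyl in place of chloro on an aromatic carbon para to a large group gives a number 1 percentage points lower from compound 2 to compound 4 (within the scatter) and leaves the two compounds indistinguishable on this read-out, so within this pair the position accepts either a 4-chlorophenyl or a 4-methylphenyl group without a step that can be read. No measurement of any property of these groups bears on this result, and the pair alone offers no explanation for it.

Going by these compounds, whether the same position would hold up with an amine, a carboxylic acid or a longer chain such as propyl in place of methyl remains open, as does whether the same exchange would give a similar step on a core carrying a different group at its other positions. The read-out is also a percentage at one concentration and not a potency, so the pair leaves open whether a full concentration series would separate compound 2 from compound 4.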